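Anilide-to-thiazolyl swap in the quinoline ether series

The source may hold more compounds than are shown below. What is called first, only, known or untested is meant among the compounds shown, and "the series" means these compounds.

Two members of the series have been run in a physicochemical assay for lipophilicity, read by HPLC, in phosphate buffer, measured as chromatographic lipophilicity, at pH 7.4; on this read-out lower numbers stand for lower lipophilicity and higher numbers for higher lipophilicity. Compound 1 `COc1ccc2nc(C)cc(OCC(=O)Nc3cc(C)cc(C)c3)c2c1` gives 5.64, the lowest of the two numbers. Going by the values given here, compound 2 `CCOc1ccc2nc(C)cc(OCC(=O)Nc3cc(C)cc(C)c3)c2c1` gives 5.98; the one measured step, a number 0.34 log units higher from compound 1 to compound 2 (beyond the scatter), is the only direct comparison so far.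

Compound 3 `COc1ccc2nc(C)cc(OCC(=O)Nc3nc(C)c(C)s3)c2c1` keeps the core of compound 1 and changes only the group on the amide nitrogen: 4,5-dimethyl-1,3-thiazol-2-yl in place of 3,5-dimethylphenyl on an amide-type nitrogen. The step from compound 1 to compound 2 concerns a methyl on a chain carbon at the aromatic ether and says nothing about exchanging the aryl group on the amide. Among the compounds with values here, no measured step in this assay bears on the change from compound 1 to compound 3. The group that enters carries two hydrogen-bond acceptors and two hetero atoms in a five-membered ring where the group that leaves had none, so the expectation for compound 3 is a step of a number 0.84 log units lower from compound 1 to compound 3 (beyond the scatter) in this assay, downward and beyond the scatter, though its size is uncertain without a comparable pair. For compound 3 the estimate in this assay is 4.8, within 4.2 to 5.4.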

Compound 3, distribution coefficient: 4.24
Estimate against measurement, compound 3: 0.56 log units above; the range from low to high includes it.
By their numbers in this assay, from the lowest: compound 3; then compound 1; then compound 2.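

The group on the amide-type nitrogen is a position to which this assay responds strongly: 4,5-dimethyl-1,3-thiazol-2-yl in place of 3,5-dimethylphenyl gives a number 1.40 log units lower from compound 1 to compound 3 (beyond the scatter), a large step. Going by these compounds alone, this is the first measured change at this nitrogen, and it runs in the opposite direction to a number 0.34 log units higher from compound 1 to compound 2 (beyond the scatter), a modest step for methyl in place of hydrogen on a saturated chain carbon bound to an oxygen on an aromatic ring. No supporting data are available to assign the step to any one feature of the entering group.

As far as these compounds go, a single exchange does not separate the contribution of the ring hetero atoms from that of the ring size or of the two methyl groups, so it remains open whether an unsubstituted 1,3-thiazol-2-yl or a pyridyl group on the amide-type nitrogen would move the number in this assay as far. From the compounds shown here alone, it is also open whether the ethoxy group of compound 2 would give a step of similar size and direction on the core of compound 3 with the 4,5-dimethyl-1,3-thiazol-2-yl group in place.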